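Swapping a ring substituent and expecting a return toward tolerance

The source may hold more compounds than are shown below. What is called first, only, known or untested is meant among the compounds shown, and "the series" means these compounds.

Measured compounds:
compound 1 `COC(=O)C[C@H](NC(=O)OC(C)(C)C)C(=O)N(Cc1ccc(F)cc1)C1(C(=O)NCc2ccccc2)CCN(Cc2ccccc2)CC1`: > 100000 nM
compound 2 `COC(=O)C[C@H](NC(=O)OC(C)(C)C)C(=O)N(Cc1ccc(F)cc1)C1(C(=O)NCc2ccccc2)CCN(C2CCCCC2)CC1`: 73000 nM

In an ADME assay on MDCK cells (Canis lupus familiaris) for cytotoxicity, read by microscopy, with a stated time of 72 h (a lower number here means that less compound is tolerated, a higher number that more compound is tolerated), compound 1 gives > 100000 nM, which is a limit of the assay rather than a number. For the measured compounds named here, compound 2 gives 73000 nM, the only actual number among the two values. Going by the values given here, the step of an at least 1.3-fold lower number from compound 1 to compound 2 (0.13 log units; that floor lies within the scatter) is the one measured comparison, and its floor lies within the scatter.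

Compound 3 `COC(=O)C[C@H](NC(=O)OC(C)(C)C)C(=O)N(Cc1ccc(F)cc1)C1(C(=O)NCc2ccccc2)CCN(Cc2cccc(F)c2)CC1` differs from compound 2 by 3-fluorobenzyl in place of cyclohexyl on an amine nitrogen in a ring. This largely reverses the measured step, returning from cyclohexyl to a benzyl-type group, so the expectation for compound 3 in this assay is a movement back toward the limit seen for compound 1, consistent with the limit of > 100000 nM in this assay, at which 1 of the 2 values shown sits. The expected step is a 1.4-fold higher number from compound 2 to compound 3 (0.14 log units; within the scatter), a modest rise that may be within the scatter. Compound 3 is therefore estimated at 100000 nM, with a range from 50000 nM to 200000 nM.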

Compound 3, minimum cytotoxic concentration: 84000 nM
For compound 3 the middle estimate is 1.2-fold (0.08 log units) above the measured one, and the stated range covers the measured number.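

In this assay, 3-fluorobenzyl in place of cyclohexyl on the amine nitrogen gives a 1.2-fold higher number from compound 2 to compound 3 (0.06 log units; within the scatter), so an aromatic ring and a non-aromatic carbon ring at this position cannot be told apart here. Fluoro in place of hydrogen on an aromatic carbon of the benzyl group gives an at least 1.1-fold lower number from compound 1 to compound 3 (0.07 log units; that floor lies within the scatter). That figure is only a floor, because compound 1 stands at a limit of the assay and not at a number: the limit of > 100000 nM in this assay, at which 1 of the 3 values shown sits.

Still open, going by these compounds, is whether any group on this nitrogen can give a step beyond the scatter, for example a short chain ending in a carboxylic acid or an acetyl group. Also open, on these data alone, is how large the true gap is between compound 1 and compound 3.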